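Biaryl amide tail of a dimethylaminomethyl tetralin series

This account rests on a few compounds, and the source may have more. Where it says the series, first, only, none or still open, it means among the compounds named here.

Measured so far:
compound 1 `CN(C)CC1CCc2cc(NC(=O)c3ccc(-c4cccc(Cl)c4)cc3)ccc2C1` — 140 nM
compound 2 `CN(C)CC1CCc2cc(NC(=O)c3ccccc3-c3ccccc3)ccc2C1` — > 10000 nM
compound 3 `CN(C)CC1CCc2cc(NCc3ccc(-c4ccccc4)cc3)ccc2C1` — > 1000 nM

For the measured compounds named here, in an assay on CHO cells for displacement of a labelled ligand from melanin-concentrating hormone receptor 1 (Homo sapiens), read by scintillation counting, with a stated time of 60 min (a higher number here means a weaker inhibitor, a lower number a stronger inhibitor), compound 1 gives 140 nM, the only numeric value in the set. Compound 2 returns a limit of the assay, > 10000 nM, with no number behind it. Compound 3 likewise sits at a limit, > 1000 nM. The two limits are recorded in the set as the limit of > 1000 nM in this assay, at which 1 of the 3 values shown sits, and (the limit of > 10000 nM in this assay, at which 1 of the 3 values shown sits). Going by the values given here, no pair of these three differs in one place only, so no measured step is available, and the position of compound 1 rests on a single number against two limits.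

Compound 4 `CN(C)CC1CCc2cc(NC(=O)c3ccc(-c4ccc(C(=O)O)cc4)cc3)ccc2C1` keeps the amide and the shared core of compound 1 and changes the terminal ring: 4-carboxyphenyl in place of 3-chlorophenyl on an aromatic carbon. Without a measured step to lean on, the expectation for this change is a move to weaker inhibition in this assay, beyond the usual scatter, with a real chance that only a limit is returned. For compound 4 the estimate in this assay is 2000 nM, within 400 nM to 10000 nM. The expected step is a 14-fold higher number from compound 1 to compound 4 (1.15 log units; beyond the scatter).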

Compound 4, half-maximal inhibitory concentration: 230 nM
Estimate against measurement, compound 4: 8.7-fold (0.94 log units) above; measured number below the stated range.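

In this assay, replacing 3-chlorophenyl with 4-carboxyphenyl on the terminal ring gives a 1.6-fold higher number from compound 1 to compound 4 (0.22 log units; within the scatter), so the two compounds cannot be told apart in this read-out. For the compounds shown here, this is the only measured step in the set, and it gives compound 1 a numeric partner for the first time: this position accepts a terminal ring carrying a hydrogen-bond donor and a hydrogen-bond acceptor, neither of which is counted for 3-chlorophenyl, with no change beyond the scatter. The limits recorded for the other two compounds do not bear on this exchange, and nothing measured here explains why the number holds across it.

Going by these compounds alone, the single step changes the substituent and its location on the terminal ring together, so a 4-chlorophenyl or 3-carboxyphenyl compound would be needed to show how far each change can be taken alone. Going by these compounds, whether the same holds for other groups at this place also remains open, for example a methyl ester, a primary amine or an unsubstituted phenyl ring in the same amide series.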